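This account rests on a few compounds, and the source may have more. Where it says the series, first, only, none or still open, it means among the compounds named here.

Measured so far, in a functional assay on HepG2 cells (Homo sapiens) for antiproliferative activity, read by CCK-8 assay, with a stated time of 72 h; a higher number here means a weaker inhibitor, a lower number a stronger inhibitor: compound 1 `COc1ccccc1C(=O)Nc1cccc(-c2oc3cc(-c4ccc(F)cc4)ccc3c(=O)c2O)c1` gives 14500 nM; compound 2 `COc1ccc(C(=O)Nc2cccc(-c3oc4cc(-c5ccc(F)cc5)ccc4c(=O)c3O)c2)c(F)c1` gives 45300 nM.

Compound 2 stands highest of the two numbers, its nearest neighbour being compound 1, reached by the step of a 3.1-fold higher number from compound 1 to compound 2 (0.49 log units; beyond the scatter). Compound 3 `O=C(Nc1cccc(-c2oc3cc(-c4ccc(F)cc4)ccc3c(=O)c2O)c1)c1cnc(Cl)nc1Cl` differs from compound 2 only at the amide: 2,4-dichloropyrimidin-5-yl in place of 2-fluoro-4-methoxyphenyl on a carbonyl carbon. For the measured compounds named here, the one measured step, a 3.1-fold higher number from compound 1 to compound 2 (0.49 log units; beyond the scatter), also changed the group on the carbonyl carbon and was modest, so a change of similar or smaller size, in either direction, is expected for the step of a 1.5-fold lower number from compound 2 to compound 3 (0.18 log units; within the scatter). Compound 3 is therefore estimated at 30000 nM in this assay, within the range 8000 nM to 120000 nM.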

Compound 3, half-maximal inhibitory concentration: > 100000 nM
Compound 3: no number, only a limit; the forecaster's own chance of this, stated with the estimate: 15%; middle value at least 3.3-fold (0.52 log units) away from the limit.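

In this assay compound 3 gives no number, only a limit of the assay: the limit of > 100000 nM in this assay, at which 1 of the 3 values shown sits.

Placing 2,4-dichloropyrimidin-5-yl on the carbonyl carbon gives an at least 2.2-fold higher number from compound 2 to compound 3 (0.34 log units; beyond the scatter), and the comparison with the 2-methoxyphenyl amide gives an at least 6.8-fold higher number from compound 1 to compound 3 (0.83 log units; beyond the scatter). The group at this position can therefore carry the number out of the measurable range, which the earlier change between two carbon-only rings did not show.

From the compounds shown here alone, the ring nitrogens and the chlorines enter together, so their shares in this step cannot be told apart, and the true size of both steps stays unknown. Going by these compounds, how a pyrimidine bearing an amine instead of the chlorines would read remains open.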